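A few compounds are considered here, and "the series" means these few. Any claim that something is new, unique, unknown or untested is made for them only; others in the source may bear on it.

Working notes on the series. In an ADME assay on Caco-2 cells (Homo sapiens) for permeability, read by LC-MS, in the apical to basolateral direction (on this read-out lower numbers stand for lower permeability and higher numbers for higher permeability), compound 1 (`CNC(=O)c1ccc(-c2ccc(O[C@H]3O[C@H](CO)[C@@H](O)[C@H](O)[C@@H]3O)cc2)cc1`) gives 1.1 10^-6 cm/s. Among the measured compounds shown here, compound 2 (`O=C(c1ccc(-c2ccc(O[C@H]3O[C@H](CO)[C@@H](O)[C@H](O)[C@@H]3O)cc2)cc1)N1CCOCC1`) gives 0.18 10^-6 cm/s, the lowest of the two numbers so far. For the measured compounds named here, the one measured step, with morpholin-4-yl in place of methylamino on a carbonyl carbon, is a 6.1-fold lower number from compound 1 to compound 2 (0.79 log units; beyond the scatter), and it lies beyond the scatter.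

Compound 3 (`N#Cc1ccc(-c2ccc(O[C@H]3O[C@H](CO)[C@@H](O)[C@H](O)[C@@H]3O)cc2)cc1`) has not yet been measured in this assay. It has cyano in place of (morpholin-4-yl)carbonyl on an aromatic carbon, para to a large group: cyano in place of (morpholin-4-yl)carbonyl on an aromatic carbon. Going by the values given here, no measured step covers this exchange, so the evidence is indirect. Among the compounds with values here, the only guide is a 6.1-fold lower number from compound 1 to compound 2 (0.79 log units; beyond the scatter), where morpholin-4-yl entered and the number fell. Here morpholin-4-yl leaves along with the carbonyl, so that step, read in reverse, points upward. Within the data shown here, the carbonyl loss has no measured precedent, which keeps the range wide. The expected step is an 11-fold higher number from compound 2 to compound 3 (1.05 log units; beyond the scatter), an upward move of similar size to the measured one. The estimate for compound 3 is 2 10^-6 cm/s, with an expected range of 0.5 10^-6 cm/s to 8 10^-6 cm/s.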

Compound 3, apparent permeability: 2 10^-6 cm/s
The estimate for compound 3 equals the measured number at the digits printed; the measured number falls inside the stated range.
By their numbers in this assay, from the lowest: compound 2; then compounds 1 and 3 (each within the scatter of the next).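

At this position, on an aromatic carbon para to a large group, the exchange of (morpholin-4-yl)carbonyl for cyano gives an 11-fold higher number from compound 2 to compound 3 (1.05 log units; beyond the scatter) in this assay, so the low number of compound 2 is not shared by a compound that lacks both the carbonyl and the six-membered non-aromatic ring. The other pair gives a 1.8-fold higher number from compound 1 to compound 3 (0.26 log units; within the scatter), which leaves cyano and methylcarbamoyl unseparated at this position; of the three groups shown, only (morpholin-4-yl)carbonyl stands apart, with compound 2 beyond the scatter of both compound 1 and compound 3. Nothing available here gives a measured property that would account for these differences.

The carbonyl and the morpholine ring leave together in the exchange from compound 2 to compound 3, so the compounds shown do not tell which part of the group goes with the low number; a dimethylamide or a piperidine amide at this position would bear on that question. Also open, from the compounds shown here alone, is how a carboxylic acid, a primary amine or a simple chlorine would read at this position, and whether the pattern holds with the rest of the shared core changed.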